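Swapping the chlorinated ring of compound 1 for a methoxypyridine

The source may report more compounds than this note shows. Statements on the series, on what has been measured and on what is new or still open speak of the compounds shown alone.

Compound 1 `COc1ccc(-c2cncnc2-c2cc(OC)c(OC)c(OC)c2)cc1Cl` gives 320 nM 
Compound 2 `CCOc1ccc(-c2cncnc2-c2cc(OC)c(OC)c(OC)c2)cc1Cl` gives 90 nM 

In a functional assay on HeLa cells (Homo sapiens) for antiproliferative activity, read by CCK-8 assay, with a stated time of 72 h (a higher number here means a weaker inhibitor, a lower number a stronger inhibitor), compound 1 has the higher number of the two measured compounds, making it the weaker inhibitor of the pair. Compound 3 `COc1ccc(-c2cncnc2-c2cc(OC)c(OC)c(OC)c2)nc1` has not yet been measured. It differs from compound 1 by one group on the shared core: 5-methoxypyridin-2-yl in place of 3-chloro-4-methoxyphenyl on an aromatic carbon. Among the measured compounds shown here, only one measured step touches the group that leaves (a 3.6-fold lower number from compound 1 to compound 2 (0.55 log units; beyond the scatter)), and it alters far less of that group. For the measured compounds named here, no measured compound shows this swap, so the direction is a judgement. A larger step towards a higher number is expected (a 4.7-fold higher number from compound 1 to compound 3 (0.67 log units; beyond the scatter)). Compound 3 is expected at 1500 nM (estimated range 300 nM to 8000 nM).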

Compound 3, half-maximal inhibitory concentration: 470 nM
Beside the measured number, compound 3's estimate is 3.2-fold (0.50 log units) above it; low and high end bracket the measured number.
By their numbers in this assay, from the lowest: compound 2; then compounds 1 and 3 (each within the scatter of the next).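

In this assay, the earlier step changed only the chain on the oxygen, whereas this one replaces the whole 3-chloro-4-methoxyphenyl group with 5-methoxypyridin-2-yl, giving a 1.5-fold higher number from compound 1 to compound 3 (0.17 log units; within the scatter). So at this position, the chlorine can go and a ring nitrogen can enter with no change beyond the scatter. Nothing available explains this result. Still open, going by these compounds, is how a 5-ethoxypyridin-2-yl group would compare with compound 3, which would test whether the ethyl step carries over to the new ring. An amine in place of the methoxy is also untested here.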